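The compounds below may be only part of what the source reports. "The series", "measured", "known", "first", "only" and "open" are said of these compounds alone.

Measured so far:
Compound 1, `Cc1ccccc1C(=O)NNC(=O)c1ccc(NS(=O)(=O)c2cnc(O)nc2O)cc1`: > 20000 nM
Compound 2, `Cc1ccc(C(=O)NNC(=O)c2ccc(NS(=O)(=O)c3cnc(O)nc3O)cc2)cc1`: > 20000 nM
Compound 3, `Cc1ccccc1C(=O)NNC(=O)c1cccc(NS(=O)(=O)c2cnc(O)nc2O)c1`: > 20000 nM

Of the compounds shown here, three have been tested in a functional assay on SGC-7901 cells (Homo sapiens) for antiproliferative activity, read by MTT assay, with a stated time of 24 h; a higher number here means a weaker inhibitor, a lower number a stronger inhibitor. In this assay compound 1 gives only a limit of the assay, > 20000 nM. Compound 2 likewise gives only a limit, > 20000 nM. Compound 3 also gives only a limit, > 20000 nM. All three therefore sit at the point described by the limit of > 20000 nM in this assay, at which 3 of the 3 values shown sit, and no number among them can be read as a true potency.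

Compound 2 differs from compound 1 by 4-methylphenyl in place of 2-methylphenyl on a carbonyl carbon. The step this change makes, a step that the two limits leave unreadable from compound 1 to compound 2, cannot be sized, since both ends are limits. Compound 3 shares the change of the methylphenyl position with compound 1 but is built on a different core; the difference between the two cores is not broken down here.

Compound 4, `Cc1ccc(C(=O)NNC(=O)c2cccc(NS(=O)(=O)c3cnc(O)nc3O)c2)cc1`, is not yet measured. It differs from compound 3 by 4-methylphenyl in place of 2-methylphenyl on a carbonyl carbon, the same change as that from compound 1 to compound 2, made at the same kind of place on the core of compound 3. Because a step that the two limits leave unreadable from compound 1 to compound 2 left both compounds at the limit, and because compound 3 itself sits at > 20000 nM, the expected step that the limit leaves unreadable from compound 3 to compound 4 is unlikely to pull compound 4 into the measurable range. For compound 4 the estimated value in this assay is 30000 nM, expected to lie between 15000 nM and 80000 nM, most probably again reported only as a limit.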

Compound 4, half-maximal inhibitory concentration: 10100 nM
Compound 4: middle estimate off by 3.0-fold (0.47 log units), on the high side; measured number outside the range, below it.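

In this assay, placing 4-methylphenyl in place of 2-methylphenyl on a carbonyl carbon gives, on the core of compound 3, an at least 1.9-fold lower number from compound 3 to compound 4 (0.29 log units; that floor lies within the scatter), and compound 4 is the only compound shown that reaches a measured number, 10100 nM. On the core of compound 1 the same change has a limit of the assay at both ends, and that step cannot be read; the series therefore shows a measured number after the change on one core, but it does not show that the change has the same effect on both cores, and with its floor inside the usual scatter the new step alone does not establish a real difference. The true size of the new step also stays unknown, because compound 3 is itself only a limit of the assay: the limit of > 20000 nM in this assay, at which 3 of the 4 values shown sit.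

The compounds shown carry only methylphenyl groups on this carbonyl carbon, and they leave open how a chlorophenyl, a methoxyphenyl or an aminophenyl group there would read in this assay. They also leave open whether a carboxylic acid or an amine on that aromatic ring would change the reading on either core.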